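A few compounds are considered here, and "the series" means these few. Any claim that something is new, unique, unknown or untested is made for them only; others in the source may bear on it.

Compound 1 `CCn1c(C(=O)NCCCN(C)C)ccc1C(CC)(CC)c1ccc(OCCC(O)(CC)CC)c(C)c1` gives the lowest of the two numbers available in a functional assay on HepG2 cells (Homo sapiens) for antiproliferative activity, read by MTT assay, with a stated time of 48 h (a higher number here means a weaker inhibitor, a lower number a stronger inhibitor), namely 110 nM. Compound 2 `CCn1c(C(=O)NCCN)ccc1C(CC)(CC)c1ccc(OCCC(O)(CC)CC)c(C)c1` gives 1590 nM, so amino in place of (dimethylamino)methyl on a saturated chain carbon, two bonds along the chain from an amide-type nitrogen, already costs a 14-fold higher number from compound 1 to compound 2 (1.16 log units; beyond the scatter). Compound 3 `CCOc1ccc(NC(=O)c2ccc(C(CC)(CC)c3ccc(OCCC(O)(CC)CC)c(C)c3)n2CC)cc1` reaches only the limit of this assay, > 50000 nM. Compound 4 `CCOC(=O)C(CC(=O)OC)NC(=O)c1ccc(C(CC)(CC)c2ccc(OCCC(O)(CC)CC)c(C)c2)n1CC` differs from compound 1 by a group of 11 heavy atoms (7 carbon, 4 oxygen; no ring) in place of a group of 6 heavy atoms (5 carbon, 1 nitrogen; no ring), on an amide-type nitrogen. The step of an at least 450-fold higher number from compound 1 to compound 3 (2.65 log units; beyond the scatter), which likewise removes the 3-(dimethylamino)propyl group from the amide-type nitrogen, bears most directly on it, and a 14-fold higher number from compound 1 to compound 2 (1.16 log units; beyond the scatter) points the same way. A large weakening is therefore expected, about a 230-fold higher number from compound 1 to compound 4 (2.36 log units; beyond the scatter). Compound 4 is estimated at 25000 nM, between 4000 nM and 80000 nM.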

Compound 4, half-maximal inhibitory concentration: > 50000 nM
Compound 4 was reported as a limit (the forecaster's own chance of this, stated with the estimate: 40%); middle value at least 2.0-fold (0.30 log units) from the limit.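

In this assay compound 4 gives > 50000 nM, which is a limit. The entering group has no ring, so the large loss on this amide-type nitrogen does not require the aromatic ring of the 4-ethoxyphenyl group in compound 3: the change gives an at least 450-fold higher number from compound 1 to compound 4 (2.65 log units; beyond the scatter) and an at least 31-fold higher number from compound 2 to compound 4 (1.49 log units; beyond the scatter). The step from compound 3 to compound 4 cannot be read, because both stand at the same limit: the limit of > 50000 nM in this assay, at which 2 of the 4 values shown sit.

Among these compounds, only compound 1 and compound 2 carry a nitrogen in this group, so whether that nitrogen matters remains open. A plain pentyl chain, or a longer chain ending in dimethylamino, would separate the nitrogen from chain length.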